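A few compounds are considered here, and "the series" means these few. Any claim that something is new, unique, unknown or untested is made for them only; others in the source may bear on it.

Working notes on the series, read in a physicochemical assay for acid dissociation. Compound 1 `Brc1cccc(Br)c1N(CC1CC1)C1=NCCN1` gives 10.9, compound 2 `Brc1cccc(N(CC2CC2)C2=NCCN2)c1Br` gives 11.1, and compound 3 `CCN(C1=NCCN1)c1c(Br)cccc1Br` gives 11.1. Compound 3 therefore stands level with compound 2 at the digits shown, and all three numbers lie within the usual scatter of one another.

The next compound is compound 4 `CCCCN(C1=NCCN1)c1c(Br)cccc1Br`, and the difference from compound 3 is ethyl in place of hydrogen on a saturated chain carbon, two bonds along the chain from a nitrogen on an aromatic ring. This is ethyl in place of hydrogen on a saturated chain carbon, two bonds along the chain from a nitrogen on an aromatic ring, so that ethyl becomes butyl.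

Within the data shown here, only one measured step bears on this change, a different alteration at the same chain: a number 0.20 log units higher from compound 1 to compound 3 (within the scatter). On that evidence, no step beyond the scatter is expected in this assay, and no direction can be assigned. The estimated step is no change at the digits printed from compound 3 to compound 4 (within the scatter). For compound 4 the expected value is 11.1, with an estimated range of 10.8 to 11.4.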

Compound 4, acid dissociation constant: 11
For compound 4 the middle estimate is 0.10 log units above the measured one; the range from low to high includes it.
By their numbers in this assay, from the lowest: compounds 1, 4, 2 and 3 (each within the scatter of the next).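

In this assay, ethyl in place of hydrogen on a saturated chain carbon, two bonds along the chain from a nitrogen on an aromatic ring, turns ethyl into butyl and reads as a number 0.10 log units lower from compound 3 to compound 4 (within the scatter). The change from the cyclopropylmethyl chain to the butyl chain reads as a number 0.10 log units higher from compound 1 to compound 4 (within the scatter), so the ethyl, butyl and cyclopropylmethyl forms of this chain, in compound 3, compound 4 and compound 1, stand within the scatter of one another. No measurement in hand speaks to the reason for these readings.

Open, from the compounds shown here alone, is whether a longer chain, or an amine or a carboxylic acid carried on this chain, would give a step beyond the scatter. Also open, going by these compounds, is whether butyl on the core of compound 2 would read as it does on the core of compound 3.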